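This account rests on a few compounds, and the source may have more. Where it says the series, first, only, none or still open, it means among the compounds named here.

In a functional assay on A549 cells (Homo sapiens) for antiproliferative activity, read by MTT assay, with a stated time of 72 h (a lower number here means a stronger inhibitor, a higher number a weaker inhibitor), compound 1 `N#Cc1ccc(/C=N/NC(=O)Nc2ccc(Oc3ccnc4[nH]ccc34)c(F)c2)cc1` gives 1360 nM, compound 3 `O=C(N/N=C/c1ccc(F)cc1Cl)Nc1ccc(Oc2ccnc3[nH]ccc23)c(F)c1` gives 10 nM, and compound 2 `O=C(N/N=C/c1cccc([N+](=O)[O-])c1)Nc1ccc(Oc2ccnc3[nH]ccc23)c(F)c1` gives 3640 nM, the highest of the three numbers. Compound 4 `O=C(N/N=C/c1ccc(O)cc1)Nc1ccc(Oc2ccnc3[nH]ccc23)c(F)c1` carries 4-hydroxyphenyl in place of 3-nitrophenyl on a carbon with a double bond to nitrogen. All three measured steps change the group at this same place. The step of a 2.7-fold higher number from compound 1 to compound 2 (0.43 log units; beyond the scatter) is modest, while a 140-fold lower number from compound 1 to compound 3 (2.13 log units; beyond the scatter) and a 360-fold lower number from compound 2 to compound 3 (2.56 log units; beyond the scatter) are large. Going by the values given here, no measured compound carries 4-hydroxyphenyl, so with compound 2 at the top of the numbers, only a moderate fall is expected in this assay, with wide uncertainty. The estimated change is a 5.2-fold lower number from compound 2 to compound 4 (0.72 log units; beyond the scatter). For compound 4 the estimate is 700 nM, with an expected range of 70 nM to 4000 nM.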

Compound 4, half-maximal inhibitory concentration: 3760 nM
Beside the measured number, compound 4's estimate is 5.4-fold (0.73 log units) below it, and the stated range covers the measured number.
By their numbers in this assay, from the lowest: compound 3; then compound 1; then compounds 2 and 4 (each within the scatter of the next).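

In this assay, 4-hydroxyphenyl in place of 3-nitrophenyl gives a 1.0-fold higher number from compound 2 to compound 4 (0.01 log units; within the scatter), so this change on the carbon with a double bond to nitrogen leaves the number where it was. Hydroxy in place of cyano on an aromatic carbon gives only a 2.8-fold higher number from compound 1 to compound 4 (0.44 log units; beyond the scatter), whereas leaving 2-chloro-4-fluorophenyl gives a 380-fold higher number from compound 3 to compound 4 (2.58 log units; beyond the scatter), so among these compounds the large steps all involve compound 3. Nothing available here explains these differences. The compounds shown leave open whether the chloro or the fluoro group of compound 3 accounts for its low number. They also leave open how an aminophenyl or a carboxyphenyl group would read at this place.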